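The compounds below may be only part of what the source reports. "The series", "measured", "known", "first", "only" and "open" are said of these compounds alone.

In a functional assay on MT4 cells (Homo sapiens) for cytotoxicity (a lower number here means that less compound is tolerated, a higher number that more compound is tolerated), compound 1 `CCc1c(O)nc(SCC(=O)c2ccc(C)cc2)nc1Cc1cccc2ccccc12` gives 6000 nM, and compound 2 `CCc1c(O)nc(SCC(=O)c2ccc(OC)cc2)nc1Cc1cccc2ccccc12` gives 178000 nM. Compound 3 `CCc1c(O)nc(SCC(=O)c2ccc(F)cc2)nc1Cc1cccc2ccccc12` has only a limit, >= 240000 nM. Compound 4 `CCc1c(O)nc(SCC(=O)c2ccc(Cl)cc2)nc1Cc1cccc2ccccc12` carries chloro in place of fluoro on an aromatic carbon, para to a large group: chloro in place of fluoro on an aromatic carbon. For the measured compounds named here, no measured step makes this exact exchange, but three steps change the same place. Two are large, a 30-fold higher number from compound 1 to compound 2 (1.47 log units; beyond the scatter) and an at least 40-fold higher number from compound 1 to compound 3 (1.60 log units; beyond the scatter), while an at least 1.3-fold higher number from compound 2 to compound 3 (0.12 log units; that floor lies within the scatter) has a floor within the scatter. These show that this place can matter, so a moderate fall from the limit seems likely. The estimated step is an at least 4.0-fold lower number from compound 3 to compound 4 (0.60 log units; beyond the scatter). Compound 4 is expected at 60000 nM, within an estimated range of 12000 nM to 240000 nM.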

Compound 4, half-maximal cytotoxic concentration: 56000 nM
Compound 4: the middle estimate sits 1.1-fold (0.03 log units) above what was measured, and the stated range covers the measured number.
By their numbers in this assay, from the lowest: compound 1; then compound 4; then compound 2. At a limit, above all of these: compound 3.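

In this assay, chloro in place of fluoro at this place on the aromatic ring is a step beyond the scatter (an at least 4.2-fold lower number from compound 3 to compound 4 (0.63 log units; beyond the scatter)), so exchanging one halogen for another is not neutral here. Chloro also separates from methoxy (a 3.2-fold lower number from compound 2 to compound 4 (0.50 log units; beyond the scatter)) and from methyl (a 9.3-fold higher number from compound 1 to compound 4 (0.97 log units; beyond the scatter)), so methyl no longer stands alone against the other groups, and chloro falls between methyl and methoxy. Compound 3 is still known only as a limit: the limit of >= 240000 nM in this assay, at which 1 of the 4 values shown sits.

From the compounds shown here alone, how far the true value of compound 3 lies beyond that limit stays open. Also open, going by these compounds, is what an amine or a carboxylic acid at this place would give.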